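A para-methoxy carbamate weighed against its unsubstituted parent

This account rests on a few compounds, and the source may have more. Where it says the series, first, only, none or still open, it means among the compounds named here.

Measured compounds:
compound 1 `C=C1C(=O)OC[C@@H]1CCOC(=O)Nc1ccccc1` — 780 nM
compound 2 `C=C1C(=O)OC[C@@H]1CCOC(=O)Nc1ccccc1F` — 690 nM
compound 3 `C=C1C(=O)OC[C@H]1CCOC(=O)Nc1ccccc1` — 390 nM

Of the compounds shown here, three built on the core of compound 1 have been tested in a functional assay on RAW264.7 cells (Mus musculus) for inhibition, with a stated time of 30 min; a lower number here means a stronger inhibitor, a higher number a weaker inhibitor. In this assay compound 1 gives 780 nM, the largest of the three numbers, yet both other numbers sit within the usual scatter of it, so no order among them can be claimed. Compound 2 carries fluoro in place of hydrogen on an aromatic carbon and gives 690 nM; the step is a 1.1-fold lower number from compound 1 to compound 2 (0.05 log units; within the scatter). Compound 3 gives 390 nM; the step is a 2.0-fold lower number from compound 1 to compound 3 (0.30 log units; within the scatter), and the fact that compounds 1 and 3 differ only in the configuration as drawn means this pair differs only at the saturated ring carbon.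

Compound 4 `C=C1C(=O)OC[C@@H]1CCOC(=O)Nc1ccc(OC)cc1` is not yet measured. It differs from compound 1 as methoxy in place of hydrogen on an aromatic carbon, the new group sitting para to a large group. Among the measured compounds shown here, the only measured step that bears on an aromatic substitution is that from compound 1 to compound 2, which was small: a 1.1-fold lower number from compound 1 to compound 2 (0.05 log units; within the scatter). On that evidence no step beyond the scatter is expected in this assay for a methoxy entering at that aromatic carbon. The step from compound 1 to compound 4 is therefore estimated as a 1.1-fold lower number from compound 1 to compound 4 (0.05 log units; within the scatter). Compound 4 is expected to give about 700 nM, within a range from 300 nM to 1800 nM.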

Compound 4, half-maximal inhibitory concentration: 1090 nM
Estimate against measurement, compound 4: 1.6-fold (0.19 log units) below, and the stated range covers the measured number.
By their numbers in this assay, from the lowest: compounds 3, 2, 1 and 4 (each within the scatter of the next, the first and the last beyond it).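

In this assay, methoxy entering on an aromatic carbon of the six-membered ring, para to a large group, gives a 1.4-fold higher number from compound 1 to compound 4 (0.15 log units; within the scatter). This shows that the place accepts a substituent of 2 heavy atoms, carrying a hydrogen-bond acceptor, without a change that can be told from repeat measurement; until now, the only aromatic substitution on record was the fluoro of compound 2, and that step too lies within the scatter. Nothing available here speaks to why methoxy is accommodated at this aromatic carbon, since the one structural observation at hand concerns configuration at a saturated ring carbon and not the aromatic ring.

From the compounds shown here alone, what remains open is whether any group at this aromatic carbon can move the number beyond the scatter, for instance an amine, a carboxylic acid or a longer chain such as butoxy in place of methoxy. Going by these compounds, it is also open whether methoxy at this carbon would give a comparable result on the core of compound 3, which has the opposite configuration as drawn at the saturated ring carbon.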